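The source may hold more compounds than are shown below. What is called first, only, known or untested is meant among the compounds shown, and "the series" means these compounds.

Measured so far:
compound 1 `CN(C)C(=O)/C=C1\CCc2c(F)cc(F)cc21` gives 50 mg/kg
compound 2 `CCNC(=O)/C=C1\CCc2ccc(F)cc21` gives 70 mg/kg
compound 3 `NC(=O)/C=C1\CCc2ccc(Br)cc21` gives 96 mg/kg

In a functional assay on the whole organism with Mus musculus as the target (on this read-out lower numbers stand for an effect already at smaller amounts and higher numbers for an effect only at larger amounts of compound), compound 2 stands at 70 mg/kg, within the usual scatter of both compound 1 at 50 mg/kg and compound 3 at 96 mg/kg. Those two also lie within the scatter of each other.

The next compound, not yet measured, is compound 4 `O=C(/C=C1\CCc2ccc(F)cc21)NC1CCC1`. It carries cyclobutyl in place of ethyl on an amide-type nitrogen, (cyclobutyl in place of ethyl on an amide-type nitrogen), and the rest of compound 2 stays as it is.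

Among the measured compounds shown here, no two measured compounds differ in one place only, so the data give no direct reading of a change on that nitrogen. The measured compounds differ from one another in more than one place, yet compound 1 at 50 mg/kg and compound 3 at 96 mg/kg remain within the scatter of each other. On that basis, no step beyond the scatter is expected in this assay, and the data support no firm direction. The estimated change is a 1.1-fold lower number from compound 2 to compound 4 (0.03 log units; within the scatter), which is expected to stay within the scatter. Compound 4 is expected at 65 mg/kg, with an estimated range from 32 mg/kg to 130 mg/kg for the coming measurement.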

Compound 4, dose for half-maximal effect: > 100 mg/kg
Compound 4 ended at the assay's limit; the forecaster's own chance of this, stated with the estimate: 5%; at least 1.5-fold (0.18 log units) between middle value and limit.
By their numbers in this assay, from the lowest: compounds 1, 2 and 3 (each within the scatter of the next). At a limit, above all of these: compound 4.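

In this assay compound 4 gives > 100 mg/kg, which is a limit of the assay and not a number. Among the compounds shown here, this is the first change that can be read at a single place, on an amide-type nitrogen whose other neighbour is the carbonyl carbon, and with cyclobutyl in place of ethyl it gives an at least 1.4-fold higher number from compound 2 to compound 4 (0.15 log units; that floor lies within the scatter), so the direction is toward a higher number, while the size that can be claimed does not pass the scatter and neither a real loss nor a flat position is established. The reading therefore has a floor and no upper bound: the limit of > 100 mg/kg in this assay, at which 1 of the 4 values shown sits.

A butyl chain or a cyclopropyl group on the same nitrogen would help separate the effect of the ring from that of the added carbons, and the compounds shown do not settle which of the two matters. Also open, on these data alone, are how far the true value of compound 4 lies beyond the limit and whether the same change on this nitrogen reads alike with other substituents on the shared core.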